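Turning one ring stereocentre in compound 2

This account rests on a few compounds, and the source may have more. Where it says the series, first, only, none or still open, it means among the compounds named here.

Compound 1 `C[C@H]1C[C@H]1C(=O)N1CC2CNCC2C1` — 18 nM
Compound 2 `C[C@@H]1C[C@@H]1C(=O)N1CC2CNCC2C1` — 1 nM

Going by the values given here, in an assay on SHEP1 cells for displacement of a labelled ligand from Neuronal acetylcholine receptor; alpha4/beta2 (Homo sapiens), read by scintillation counting, with a stated time of 2 h (on this read-out lower numbers stand for stronger inhibition and higher numbers for weaker inhibition), compound 2 gives 1 nM, the lowest of the two numbers so far. Compound 1 gives 18 nM. The two share every atom and bond; the step is an 18-fold lower number from compound 1 to compound 2 (1.26 log units; beyond the scatter), and the only thing that separates them is the fact that one of compounds 1 and 2 is drawn with a defined configuration and the other without, at the place where they differ — both ring stereocentres are drawn the opposite way round.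

Compound 3 `C[C@@H]1C[C@H]1C(=O)N1CC2CNCC2C1` is still to be measured. It differs from compound 2 in this way: the two compounds have the same atoms and bonds; at least one stereo element is drawn with a configuration in one of them and without one in the other: 1 of 4 stereo elements differ; a stereocentre at a saturated ring carbon is drawn S in compound 2 and R in compound 3. Among the compounds with values here, only the step between compound 1 and compound 2 bears on it, and that step shows that how these ring centres are drawn can move the number a long way. Turning a single centre is a different change, and its direction cannot be read from one pair. A step of an 8.0-fold higher number from compound 2 to compound 3 (0.90 log units; beyond the scatter) is expected, leaning towards a weaker result. Compound 3 is estimated at 8 nM, within a range from 2 nM to 40 nM.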

Compound 3, inhibition constant: 4 nM
Compound 3: the middle estimate sits 2.0-fold (0.30 log units) above what was measured, within the range that was stated.
By their numbers in this assay, from the lowest: compound 2; then compound 3; then compound 1.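

In this assay, each ring stereocentre can now be seen acting on its own, which the pair of compounds 1 and 2 could not show because both centres change together there. Turning one centre gives a 4.0-fold higher number from compound 2 to compound 3 (0.60 log units; beyond the scatter), and turning the other gives a 4.5-fold lower number from compound 1 to compound 3 (0.65 log units; beyond the scatter). Both steps are modest yet beyond the scatter, so neither centre alone accounts for the whole gap, and compound 3 falls between the other two compounds.

The compounds shown leave open how the remaining arrangement of these two ring centres would read, since only three arrangements appear here. They also leave open whether this order would hold if the methyl group on the ring gave way to an ethyl group or a longer chain.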